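Replacing a bicyclic amine with a trifluoromethyl acid chain

The compounds below may be only part of what the source reports. "The series", "measured", "known", "first", "only" and "open" are said of these compounds alone.

Compound 1 `COC(=O)C1=C(CN2CC3CC2CO3)NC(c2nccs2)=NC1(C)c1ccc(F)cc1` carries a group of 7 heavy atoms (5 carbon, 1 nitrogen, 1 oxygen; 2 five-membered non-aromatic rings with 1 hetero atom each) on a saturated chain carbon bound to a double-bonded ring carbon. For the measured compounds named here, in an ADME assay on microsomes from liver (Mus musculus) for metabolic stability, read by LC-MS, using NADPH, with stated times of 10 min and 30 min, tested at 1 uM (a higher number here means faster removal of the compound, a lower number slower removal), compound 1 gives 84 mL/min/kg, the highest of the two numbers recorded, although its only neighbour, compound 2 `COC(=O)C1=C(CN2CCCS2(=O)=O)NC(c2nccs2)=NC1(C)c1ccc(F)cc1`, which gives 79 mL/min/kg, lies within the scatter of it. The step of a 1.1-fold lower number from compound 1 to compound 2 (0.03 log units; within the scatter) shows that one exchange of the group on that saturated chain carbon left the clearance essentially where it was.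

Compound 3 `COC(=O)C1=C(COC(C(=O)O)C(F)(F)F)NC(c2nccs2)=NC1(C)c1ccc(F)cc1` is the next case at the same saturated chain carbon. The change is a group of 9 heavy atoms (3 carbon, 3 oxygen, 3 fluorine; no ring) in place of a group of 7 heavy atoms (5 carbon, 1 nitrogen, 1 oxygen; 2 five-membered non-aromatic rings with 1 hetero atom each), on a saturated chain carbon bound to a double-bonded ring carbon. Going by the values given here, no measured step matches this exchange: the entering group has no ring, whereas both groups measured so far were cyclic. Among the compounds with values here, the one comparison available, the step from compound 1 to compound 2, was within the scatter and offers no direction. The expected step of a 1.5-fold lower number from compound 1 to compound 3 (0.18 log units; within the scatter) is therefore modest, leaning toward a lower number but not confidently beyond the scatter. Compound 3 is estimated at 55 mL/min/kg, with a range from 25 mL/min/kg to 110 mL/min/kg.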

Compound 3, clearance: 24 mL/min/kg
Compound 3: middle estimate off by 2.3-fold (0.36 log units), on the high side; measured number outside the range, below it.
By their numbers in this assay, from the lowest: compound 3; then compounds 2 and 1 (each within the scatter of the next).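

At the saturated chain carbon bound to a double-bonded ring carbon, this assay had so far shown no movement between two cyclic groups, but the group of 9 heavy atoms with no ring gives a 3.5-fold lower number from compound 1 to compound 3 (0.54 log units; beyond the scatter) and also a 3.3-fold lower number from compound 2 to compound 3 (0.52 log units; beyond the scatter) as the first changes here to lie beyond the scatter. The two steps read alike, so among these three compounds the lower clearance does not depend on which cyclic group leaves. No measurement at hand gives a reason for this lower clearance.

The entering group differs from both cyclic groups in several ways at once, with a carboxylic acid, a trifluoromethyl and no ring, and the compounds shown do not separate these features. From the compounds shown here alone, how the clearance would read with a methyl ester in place of the carboxylic acid, with a hydrogen in place of the trifluoromethyl, or with a longer chain carrying the carboxylic acid remains open, as does whether the same exchange would act alike on another core.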